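The source may report more compounds than this note shows. Statements on the series, on what has been measured and on what is new or still open speak of the compounds shown alone.

Working notes on the series. In a functional assay on NCI-H460 cells (Homo sapiens) for positive allosteric modulation, read by MTT assay, with stated times of 2 h and 72 h, tested at 1 uM (on this read-out higher numbers stand for weaker inhibition and lower numbers for stronger inhibition), compound 1 `CCCc1ccc(C(=O)Nc2ccccc2-c2nnn(-c3cccc(OC)c3)n2)cc1` gives 207 nM, compound 2 `COc1cccc(-n2nnc(-c3ccccc3NC(=O)c3ccc(NC(C)=O)cc3)n2)c1` gives 725 nM and compound 3 `COc1cccc(-n2nnc(-c3ccccc3NC(=O)Nc3ccc([N+](=O)[O-])cc3)n2)c1` gives 179 nM. Compound 3 is level with compound 1, as a 1.2-fold lower number from compound 1 to compound 3 (0.06 log units; within the scatter) shows, and clearly separated from compound 2, as a 4.1-fold lower number from compound 2 to compound 3 (0.61 log units; beyond the scatter) shows.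

Compound 4 `COc1cccc(-n2nnc(-c3ccccc3NC(=O)Nc3ccc(N)cc3)n2)c1` differs from compound 3 in one place: amino in place of nitro on an aromatic carbon. This is amino in place of nitro on an aromatic carbon. Going by the values given here, no measured pair makes this exchange, so the evidence is indirect. The closest guide is compound 2, whose acetamido group is the nearest relative of amino among the measured compounds. Acetamido in place of propyl gave a 3.5-fold higher number from compound 1 to compound 2 (0.54 log units; beyond the scatter), and the change from compound 2 gave a 4.1-fold lower number from compound 2 to compound 3 (0.61 log units; beyond the scatter), so the nitro compound and the acetamido compound lie apart in this assay. Compound 2 also differs from compound 4 in its linker, which weakens the analogy. A modest rise in the number is therefore expected, smaller than the full gap to compound 2. The expected size is a 2.2-fold higher number from compound 3 to compound 4 (0.35 log units; beyond the scatter). For compound 4 the estimated value is 400 nM, with an expected range of 150 nM to 1000 nM.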

Compound 4, half-maximal inhibitory concentration: 228 nM
For compound 4 the middle estimate is 1.8-fold (0.24 log units) above the measured one; low and high end bracket the measured number.
By their numbers in this assay, from the lowest: compounds 3, 1 and 4 (each within the scatter of the next); then compound 2.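

Working notes, continued. In this assay, exchanging nitro (3 heavy atoms, 2 hydrogen-bond acceptors, no donor) for amino (1 heavy atom, 1 hydrogen-bond donor, 1 hydrogen-bond acceptor) leaves the result within the scatter (a 1.3-fold higher number from compound 3 to compound 4 (0.11 log units; within the scatter)), so on this aromatic carbon, para to a large group, the two groups read alike despite those differences in the counts. Compound 4 is likewise level with the propyl compound (a 1.1-fold higher number from compound 1 to compound 4 (0.04 log units; within the scatter)) but clearly separated from the acetamido compound (a 3.2-fold lower number from compound 2 to compound 4 (0.50 log units; beyond the scatter)), which leaves compound 2 as the only one of the four that stands apart, with compounds 1, 3 and 4 forming a single level group. Nothing on hand explains why these groups read alike or why compound 2 stands apart.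

Still open, going by these compounds, is whether acetamido on the amino group of compound 4 would give the same rise in the number as in compound 2, which would tie that rise to the acetamido group rather than to the 4-acetamidophenyl attachment on the carbonyl carbon. Also open, on these data alone, is how a carboxylic acid, a dimethylamino group or a longer alkyl chain would read on this same aromatic carbon.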